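Swapping fluoro for methyl on the sulfonyl-linked ring

The compounds below may be only part of what the source reports. "The series", "measured", "known", "first", "only" and "open" are said of these compounds alone.

Measured so far:
compound 1, `Cc1ccc(S(=O)(=O)c2cnc3c(F)cccc3c2-c2ccc(Cl)cc2)cc1F`, 2.2 mL/min
compound 2, `O=S(=O)(c1ccc(F)c(F)c1)c1cnc2c(F)cccc2c1-c1cccc(Cl)c1`, 1.13 mL/min

Both compounds were run in an ADME assay on microsomes from liver (Homo sapiens) for metabolic stability, tested at 2.5 uM; a lower number here means slower removal, a higher number faster removal of the compound. Compound 2 gives 1.13 mL/min, the lowest of the two numbers, and compound 1 gives 2.2 mL/min, which lies within the usual scatter of compound 2, so the two cannot be told apart on these numbers alone.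

Compound 3, `Cc1ccc(S(=O)(=O)c2cnc3c(F)cccc3c2-c2cccc(Cl)c2)cc1F`, has not yet been measured in this assay. Its difference from compound 2 is counted as methyl in place of fluoro on an aromatic carbon. Within the data shown here, no step between measured compounds isolates this single change, so any expectation rests only on the two values shown. Since compound 1, which also carries the 3-fluoro-4-methylphenyl group, gives 2.2 mL/min and sits within the scatter of compound 2, the expected step of a 1.6-fold higher number from compound 2 to compound 3 (0.20 log units; within the scatter) is a modest rise, not clearly beyond the scatter. Compound 3 is therefore estimated at 1.8 mL/min, with a range from 0.9 mL/min to 3.6 mL/min.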

Compound 3, intrinsic clearance in a liver preparation (reported as CLH), per the amount of preparation that the assay uses: 3.18 mL/min
Beside the measured number, compound 3's estimate is 1.8-fold (0.25 log units) below it; low and high end bracket the measured number.
By their numbers in this assay, from the lowest: compounds 2, 1 and 3 (each within the scatter of the next, the first and the last beyond it).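

Read one change at a time, the results separate the two places where these compounds differ. With everything else held constant, going from 3,4-difluorophenyl to 3-fluoro-4-methylphenyl gives a 2.8-fold higher number from compound 2 to compound 3 (0.45 log units; beyond the scatter) in this assay, so methyl in place of fluoro on this aromatic carbon is a change that can be told apart from assay noise, though only modestly. By contrast, 3-chlorophenyl in place of 4-chlorophenyl gives a 1.4-fold higher number from compound 1 to compound 3 (0.16 log units; within the scatter) and so cannot be separated from the noise in these data. Nothing available here bears on why the methyl step arises.

Going by these compounds, this swap can be read on only one background, the compounds carrying the 3-chlorophenyl group, so it remains open whether the same step would appear with the 4-chlorophenyl group. On these data alone, how other groups at this position, such as an ethyl, a methoxy or a nitrile, would compare with fluoro and methyl also remains open.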